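A few compounds are considered here, and "the series" means these few. Any claim that something is new, unique, unknown or untested is made for them only; others in the source may bear on it.

Measured compounds:
compound 1 `COc1cccc(OC)c1OCCNCCOc1ccccc1OCc1ccccc1` gives 0.468 nM
compound 2 `COc1cccc(OC)c1OCCNCCOc1ccccc1OCc1ccccc1Cl` gives 1.41 nM
compound 3 `COc1cccc(OC)c1OCCNCCOc1ccccc1OCc1ccccc1C` gives 1.59 nM

All three were examined in an assay on CHO cells for displacement of a labelled ligand from Alpha-1A adrenergic receptor (Homo sapiens); on this read-out higher numbers stand for weaker inhibition and lower numbers for stronger inhibition. Compound 3 gives the highest of the three numbers; its nearest neighbour is compound 2, since a 1.1-fold higher number from compound 2 to compound 3 (0.05 log units; within the scatter), while the gap to compound 1 is wider, a 3.4-fold higher number from compound 1 to compound 3 (0.53 log units; beyond the scatter). Compound 4 `COc1cccc(OC)c1OCCNCCOc1ccccc1OCc1ccc([N+](=O)[O-])cc1` has not yet been measured. Relative to compound 3 it carries 4-nitrophenyl in place of 2-methylphenyl on a saturated chain carbon bound to an oxygen on an aromatic ring.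

Among the measured compounds shown here, two measured steps bear on this change, though only loosely: a 3.0-fold higher number from compound 1 to compound 2 (0.48 log units; beyond the scatter) and a 3.4-fold higher number from compound 1 to compound 3 (0.53 log units; beyond the scatter) both show that placing a small group on the benzyl ring, where compound 1 has only hydrogen, gives a modest rise in this assay. For the measured compounds named here, no measured step puts a nitro group on this ring, and none replaces one group on it by another at a different place, so the size of the move from compound 3 is not fixed by these data. On balance compound 4 is expected to stay close to compound 3, with a 1.3-fold higher number from compound 3 to compound 4 (0.10 log units; within the scatter) lying within the scatter. The estimate for compound 4 is 2 nM, in the range 0.6 nM to 6 nM.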

Compound 4, inhibition constant: 1.26 nM
Compound 4: middle estimate off by 1.6-fold (0.20 log units), on the high side; low and high end bracket the measured number.
By their numbers in this assay, from the lowest: compound 1; then compounds 4, 2 and 3 (each within the scatter of the next).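

In this assay, nitro behaves like chloro and methyl in one respect, with a 2.7-fold higher number from compound 1 to compound 4 (0.43 log units; beyond the scatter) as a modest step, so all three substituted compounds stand apart from compound 1. Swapping in 4-nitrophenyl, which brings hydrogen-bond acceptors that 2-methylphenyl and 2-chlorophenyl do not have, leaves the number within the scatter of both, with a 1.3-fold lower number from compound 3 to compound 4 (0.10 log units; within the scatter) and a 1.1-fold lower number from compound 2 to compound 4 (0.05 log units; within the scatter) as the two steps. Nothing in the data explains why these three groups give such similar numbers.

Going by these compounds, it remains open whether the place of a group on the ring matters in itself, as the step from 2-methylphenyl to 4-nitrophenyl alters group and place at once. On these data alone, it is also open whether an amine or a carboxylic acid on this ring would stay as close to these compounds.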